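The source may report more compounds than this note shows. Statements on the series, on what has been measured and on what is new or still open speak of the compounds shown alone.

Three compounds share one core and differ only in the group on the aromatic carbon between two ring nitrogen atoms. Compound 1 `Cc1ccc2c(NCc3ccc(NC(=O)C4CCN(Cc5ccccc5)CC4)cc3)nc(N3CCC3)nc2c1` carries azetidin-1-yl. In a functional assay on SV5A8 cells (Homo sapiens) for cytotoxicity (on this read-out lower numbers stand for stronger inhibition and higher numbers for weaker inhibition), compound 1 gives > 8500 nM, which is a limit of the assay rather than a number. Compound 2 `Cc1ccc2c(NCc3ccc(NC(=O)C4CCN(Cc5ccccc5)CC4)cc3)nc(N3CCNC(CCO)C3)nc2c1` carries 3-(2-hydroxyethyl)piperazin-1-yl; in this assay compound 2 gives > 8420 nM, again a limit. Compound 3 `Cc1ccc2c(NCc3ccc(NC(=O)C4CCN(Cc5ccccc5)CC4)cc3)nc(N3CCCC3)nc2c1` carries pyrrolidin-1-yl; in this assay compound 3 gives > 7790 nM, also a limit. So compound 3 stands, like the other two, at a limit, and the steps a step that the two limits leave unreadable from compound 1 to compound 2, a step that the two limits leave unreadable from compound 1 to compound 3 and a step that the two limits leave unreadable from compound 2 to compound 3 cannot be sized. Compound 4 `Cc1ccc2c(NCc3ccc(NC(=O)C4CCN(Cc5ccccc5)CC4)cc3)nc(N(C)CCCN(C)C)nc2c1` brings the change ((3-(dimethylamino)propyl)(methyl)amino in place of pyrrolidin-1-yl on an aromatic carbon). Going by the values given here, no measured step gives a readable size for such a change, so no step beyond the scatter is expected in this assay; the expected step from compound 3 to compound 4 is a step that the limit leaves unreadable from compound 3 to compound 4. Compound 4 is expected near 8000 nM, within 2000 nM to 30000 nM.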

Compound 4, half-maximal inhibitory concentration: > 8620 nM
Compound 4 gave a limit, no number; the forecaster's own chance of this, stated with the estimate: 75%; at least 1.0-fold (0.03 log units) between middle value and limit.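

Going by these compounds alone, compound 4 stands at a limit, as do compound 1, compound 2 and compound 3, so no step among them can be read. The compounds shown leave open whether any group at this place gives a number rather than a limit in this assay.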